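Replacing a Free Hydroxy with Butoxy

The source may report more compounds than this note shows. Statements on the series, on what has been measured and on what is new or still open speak of the compounds shown alone.

In a functional assay on SK-N-MC cells (Homo sapiens) for cytotoxicity, read by MTT assay (a higher number here means a weaker inhibitor, a lower number a stronger inhibitor), compound 1 `COc1cc(/C=C2\CCC/C(=C\c3ccc([N+](=O)[O-])cc3)C2=O)ccc1O` reads 48 ug/mL as its half-maximal inhibitory concentration. Compound 2 `COc1cc(/C=C2\CCC/C(=C\c3ccc([N+](=O)[O-])cc3)C2=O)cc(Br)c1O` stands lower of the two at 16.8 ug/mL and so is the stronger inhibitor here. Going by the values given here, the only measured step, bromo in place of hydrogen on an aromatic carbon, is a 2.9-fold lower number from compound 1 to compound 2 (0.46 log units; beyond the scatter) and counts as modest. Compound 3 `CCCCOc1c(Br)cc(/C=C2\CCC/C(=C\c3ccc([N+](=O)[O-])cc3)C2=O)cc1OC` has yet to be measured. It carries butyl in place of hydrogen on an oxygen on an aromatic ring, hydroxy to butoxy, with butyl in place of hydrogen on an oxygen on an aromatic ring as the counted change. The bromo step is a different change and gives no direct guide to this one, so no shift beyond the scatter is expected in this assay for now. Compound 2 at 16.8 ug/mL remains the anchor for that expectation. The expected change is a 1.4-fold higher number from compound 2 to compound 3 (0.15 log units; within the scatter) in size, with wide uncertainty. For compound 3 the estimate is 24 ug/mL with 7 ug/mL to 80 ug/mL as its expected range.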

Compound 3, half-maximal inhibitory concentration: 41.3 ug/mL
Compound 3: the middle estimate sits 1.7-fold (0.24 log units) below what was measured, within the range that was stated.
By their numbers in this assay, from the lowest: compound 2; then compounds 3 and 1 (each within the scatter of the next).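

In this assay, hydroxy to butoxy gives a 2.5-fold higher number from compound 2 to compound 3 (0.39 log units; beyond the scatter), so at this oxygen on an aromatic ring, butyl in place of hydrogen yields a weaker inhibitor. This single step joins two changes, the loss of the hydroxy hydrogen and the arrival of the butyl chain, and the numbers cannot separate them. No measurement at hand explains the rise.

The compounds shown leave open whether a shorter chain such as ethyl, a longer chain such as hexyl, or a chain ending in an amine or a carboxylic acid would give a number nearer to that of compound 2. Going by these compounds, whether butyl in place of this hydrogen has a similar effect without the bromo also stays open.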